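Series notes: substituent swap on the arylamino group

The compounds below may be only part of what the source reports. "The series", "measured", "known", "first", "only" and "open" are said of these compounds alone.

Measured so far in a functional assay on HGC-27 cells (Homo sapiens) for cytotoxicity, read by MTT assay, with a stated time of 72 h; on this read-out lower numbers stand for stronger inhibition and higher numbers for weaker inhibition:
Compound 1 `FC(F)(F)c1ccc(CSc2nc(N3CCCCC3)c3ccccc3n2)cc1` gives only a limit, > 50000 nM.
Compound 2 `FC(F)(F)c1ccc(CSc2nc(Nc3ccc(Cl)cc3)c3ccccc3n2)cc1` gives 14100 nM.

Compound 2 holds the only number shown in this assay; the other value, for compound 1, is a limit (the limit of > 50000 nM in this assay, at which 1 of the 2 values shown sits). Among the measured compounds shown here, the single measured step, an at least 3.5-fold lower number from compound 1 to compound 2 (0.54 log units; beyond the scatter), is beyond the scatter and concerns the exchange of the whole amine on the shared core.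

Compound 3 `COc1ccc(Nc2nc(SCc3ccc(C(F)(F)F)cc3)nc3ccccc23)cc1OC` differs from compound 2 by 3,4-dimethoxyphenyl in place of 4-chlorophenyl on a nitrogen on an aromatic ring. For the measured compounds named here, no measured step bears on that change: the step from compound 1 to compound 2 replaces one amine by another and carries no information on substituents of the arylamino ring. The working expectation is therefore no step beyond the scatter, a 1.1-fold higher number from compound 2 to compound 3 (0.03 log units; within the scatter), in this assay. For compound 3 the estimate is 15000 nM, with a range from 5000 nM to 50000 nM.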

Compound 3, half-maximal inhibitory concentration: 17900 nM
Estimate against measurement, compound 3: 1.2-fold (0.08 log units) below; the range from low to high includes it.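

In this assay, 3,4-dimethoxyphenyl in place of 4-chlorophenyl on a nitrogen on an aromatic ring gives a 1.3-fold higher number from compound 2 to compound 3 (0.10 log units; within the scatter), so the first change made on the arylamino ring itself leaves the number within the scatter. The advantage over the piperidin-1-yl amine therefore does not depend on the 4-chlorophenyl group alone, and the second arylamino compound also separates from that amine: an at least 2.7-fold lower number from compound 1 to compound 3 (0.44 log units; beyond the scatter). This step is a bound and not a size, since compound 1 gives only a limit: the limit of > 50000 nM in this assay, at which 1 of the 3 values shown sits.

From the compounds shown here alone, whether an unsubstituted phenyl group or a carboxylic acid on the arylamino ring would move the number beyond the scatter stays open. So does the outcome of exchanging the trifluoromethyl group shared by all three compounds for a nitrile.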